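Swapping an azidophenyl amide for a phenethyl amide

The source may hold more compounds than are shown below. What is called first, only, known or untested is meant among the compounds shown, and "the series" means these compounds.

Measured compounds:
compound 1 `N#CN/C(=N\CCCNc1ccc(N=[N+]=[N-])cc1[N+](=O)[O-])NCCCCOc1cccc(CN2CCCCC2)c1` gives 6.56
compound 2 `N#CN/C(=N\CCCNC(=O)c1ccc(N=[N+]=[N-])cc1)NCCCOc1cccc(CN2CCCCC2)c1` gives 6.36
compound 3 `N#CN/C(=N\CCNC(=O)c1ccccc1)NCCCCOc1cccc(CN2CCCCC2)c1` gives 7.67

All three were tested in a functional assay on cardiac atrium for antagonist activity at histamine H2 receptor (Cavia porcellus); a higher number here means a more potent compound, by a factor of ten per unit of this negative logarithm, a lower number a less potent compound. Compound 2 sits at the low end of the three numbers: compound 1 lies close enough that the two cannot be told apart, while compound 3 sits clearly higher. Compound 4 `N#CN/C(=N\CCCNC(=O)CCc1ccccc1)NCCCOc1cccc(CN2CCCCC2)c1` differs from compound 2 in one place: phenethyl in place of 4-azidophenyl on a carbonyl carbon. For the measured compounds named here, no measured pair shows this exact change, so the direction is uncertain. Compound 3, which also lacks an azide on its amide aryl, gives 7.67, the highest number shown, which suggests an azide is not needed. For compound 4 a small upward step is expected, a number 0.34 log units higher from compound 2 to compound 4 (beyond the scatter), giving an estimated 6.7 with a range from 6 to 7.4.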

Compound 4, negative logarithm of the antagonist equilibrium constant: 6.07
Compound 4: the middle estimate sits 0.63 log units above what was measured, within the range that was stated.
By their numbers in this assay, from the lowest: compounds 4, 2 and 1 (each within the scatter of the next, the first and the last beyond it); then compound 3.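

In this assay the swap of phenethyl in place of 4-azidophenyl on a carbonyl carbon reads a number 0.29 log units lower from compound 2 to compound 4 (within the scatter) and so cannot be told from no change. This direct comparison shows that, on this core, the azide-bearing ring can give way to an all-carbon group without a clear shift in the number. Nothing given here explains this result.

From the compounds shown here alone, whether a benzyl group or a carboxylic acid on this carbonyl carbon would move the number remains open. So does whether the same swap would read alike on the core of compound 3.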